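Hydroxyl Enters the Outer Ring of Compound 3

This account rests on a few compounds, and the source may have more. Where it says the series, first, only, none or still open, it means among the compounds named here.

Three compounds share one core. In a functional assay for inhibition, tested at 100 ug/mL (on this read-out lower numbers stand for a weaker effect and higher numbers for a stronger effect at the one concentration tested), compound 1 `COc1cc(-c2cc(-c3cc(C(C)C)c(O)cc3C)[nH]c(=O)c2C#N)cc(OC)c1OC` gives 84.5%, compound 2 `COc1cccc(-c2cc(-c3cc(C(C)C)c(O)cc3C)[nH]c(=O)c2C#N)c1` gives 49%, and compound 3 `COc1ccc(-c2cc(-c3cc(C(C)C)c(O)cc3C)[nH]c(=O)c2C#N)c(OC)c1` gives 58%. Compound 3 thus stands second highest of the three: its nearest neighbour is compound 2, within the scatter, while compound 1 sits beyond the scatter above it. Compound 4 `COc1cc(-c2cc(-c3cc(C(C)C)c(O)cc3C)[nH]c(=O)c2C#N)ccc1O` carries 4-hydroxy-3-methoxyphenyl in place of 2,4-dimethoxyphenyl on an aromatic carbon. Going by the values given here, the only measured step, a number 9 percentage points higher from compound 2 to compound 3 (within the scatter), exchanged one methoxyphenyl group for another and stayed within the scatter; no measured step brings in a hydroxyl, so the numbers offer no pull in either direction. Compound 4 is therefore expected to move by a number 3 percentage points lower from compound 3 to compound 4 (within the scatter), nothing beyond the scatter. The estimate for compound 4 is 55%, ranging from 30% to 80%.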

Compound 4, a percentage reported as inhibition, at one concentration (the size of the read-out at that concentration, not a potency): 44%
Compound 4: middle estimate off by 11 percentage points, on the high side, and the stated range covers the measured number.
By their numbers in this assay, from the lowest: compounds 4, 2 and 3 (each within the scatter of the next, the first and the last beyond it); then compound 1.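

In this assay, going by these compounds alone, moving to the 4-hydroxy-3-methoxyphenyl group gives a number 14 percentage points lower from compound 3 to compound 4 (beyond the scatter), the first step at this position to pass beyond the scatter, so this outer ring does respond to a change in its groups. Yet hydroxy in place of hydrogen on the 3-methoxyphenyl ring gives a number 5 percentage points lower from compound 2 to compound 4 (within the scatter), so adding the hydroxyl alone brings no clear change in either direction. On these data alone, whether an amine or a carboxylic acid on this outer ring would give a similar number remains open. Nothing available explains either step.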